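A Basic Side Chain in Place of the Allyl Group

The source may report more compounds than this note shows. Statements on the series, on what has been measured and on what is new or still open speak of the compounds shown alone.

Compound 1, `Cn1ncc(Cl)c1-c1cc(C(=O)N[C@@H]2CNCC[C@H]2c2ccc(C(F)(F)F)cc2)oc1Cl`, gives 280 nM in a functional assay on HCT-116 cells (Homo sapiens) for antiproliferative activity, read by sulforhodamine B assay, with a stated time of 72 h; on this read-out lower numbers stand for stronger inhibition and higher numbers for weaker inhibition.
Compound 2, `C=CC[C@@H]1C[C@@H](c2ccc(Cl)c(Cl)c2)[C@H](NC(=O)c2cc(-c3c(Cl)cnn3C)c(Cl)o2)CN1`, gives 780 nM in this assay.

Of the two measured compounds, compound 2 carries the higher number in this assay, and the gap to compound 1 lies beyond the usual scatter of the assay. For the measured compounds named here, the two compounds differ in several places at once, so the gap between them cannot be traced to any single change and no step between them is given.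

Compound 3, `CN(C)CC[C@@H]1C[C@@H](c2ccc(Cl)c(Cl)c2)[C@H](NC(=O)c2cc(-c3c(Cl)cnn3C)c(Cl)o2)CN1`, has not yet been measured. It differs from compound 2 in one place: (dimethylamino)methyl in place of vinyl on a saturated chain carbon bound to a saturated ring carbon. Cut one bond further out, the same difference reads as allyl to 2-(dimethylamino)ethyl.

Going by the values given here, no measured pair shows what such a change does on this shared core, so the expectation rests on compound 2 alone. The expected step is a 1.1-fold lower number from compound 2 to compound 3 (0.05 log units; within the scatter), with no clear direction and of a size that stays within the scatter. Compound 3 is therefore expected to give about 700 nM in this assay, with a range estimated from 250 nM to 2000 nM.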

Compound 3, half-maximal inhibitory concentration: 1710 nM
Beside the measured number, compound 3's estimate is 2.4-fold (0.39 log units) below it; measured number inside the range.
By their numbers in this assay, from the lowest: compound 1; then compound 2; then compound 3.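

For the compounds shown here, exchanging allyl for 2-(dimethylamino)ethyl gives the first measured step at this position: in this assay it produces a 2.2-fold higher number from compound 2 to compound 3 (0.34 log units; beyond the scatter) and so moves the read-out toward weaker inhibition. The saturated chain carbon bound to a saturated ring carbon therefore does not tolerate every group equally, and this exchange of vinyl for (dimethylamino)methyl, which adds a nitrogen and a hydrogen-bond acceptor, carries a modest cost on the shared core. No measurement among these compounds explains the loss.

The compounds shown leave open whether the loss follows the nitrogen or the larger group, as both enter together in this single step. A butyl chain would speak to the size of the group without a nitrogen, while a primary amine or a carboxylic acid at the end of the chain would show whether other groups in that place follow the same direction.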